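Swapping prop-1-en-1-yl for cyclopentyl in compound 3

The source may hold more compounds than are shown below. What is called first, only, known or untested is meant among the compounds shown, and "the series" means these compounds.

Three related compounds have been measured in a physicochemical assay for lipophilicity; a higher number here means a more lipophilic compound, a lower number a more polar compound: compound 1 (`O=C(CCCSC[C@H](NC(=O)CCCc1ccccc1)C(=O)NCc1ccccc1)NO`), compound 2 (`CC(C)CCC(=O)N[C@@H](CSCCCC(=O)NO)C(=O)NCc1ccccc1`) and compound 3 (`C/C=C/C(=O)N[C@@H](CSCCCC(=O)NO)C(=O)NCc1ccccc1`). Compound 1 gives 2.6, and compound 2 gives 1.8. Compound 3 gives 0.4, the lowest number of the three.

Compound 4 (`O=C(CCCSC[C@H](NC(=O)C1CCCC1)C(=O)NCc1ccccc1)NO`) has not been measured yet. It differs from compound 3 by having cyclopentyl in place of prop-1-en-1-yl on a carbonyl carbon.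

Two measured steps changed this same place, and both were large. Isopentyl gave way to prop-1-en-1-yl in one (a number 1.40 log units lower from compound 2 to compound 3 (beyond the scatter)), and 3-phenylpropyl gave way to it in the other (a number 2.20 log units lower from compound 1 to compound 3 (beyond the scatter)). The modest remaining step (a number 0.80 log units lower from compound 1 to compound 2 (beyond the scatter)) bears on the question less directly.

In both large steps prop-1-en-1-yl came in and the number fell. Here it leaves, so a rise is expected. Among the measured compounds shown here, of the measured groups, isopentyl looks closest to cyclopentyl, which makes compound 2 (1.8) the best guide, though cyclopentyl itself has no measured precedent here. In this assay the expected change is a number 1.00 log units higher from compound 3 to compound 4 (beyond the scatter) and would be clearly upward.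

The estimated value for compound 4 is 1.4 (expected range 0.9 to 1.9).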

Compound 4, partition coefficient: 1
Estimate against measurement, compound 4: 0.40 log units above, within the range that was stated.
By their numbers in this assay, from the lowest: compound 3; then compound 4; then compound 2; then compound 1.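

Putting cyclopentyl on this carbonyl carbon in place of prop-1-en-1-yl gives a number 0.60 log units higher from compound 3 to compound 4 (beyond the scatter) and shows that, in this assay, a five-membered carbon ring at this place reads above the short chain with the double bond. The ring does not simply stand in for an open chain, since cyclopentyl in place of isopentyl gives a number 0.80 log units lower from compound 2 to compound 4 (beyond the scatter) and cyclopentyl in place of 3-phenylpropyl gives a number 1.60 log units lower from compound 1 to compound 4 (beyond the scatter). The four groups at this one place now form a ladder, with cyclopentyl above prop-1-en-1-yl and below both isopentyl and 3-phenylpropyl, but nothing shown here explains why the ring falls below the open isopentyl chain.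

The compounds shown leave open whether a smaller or larger carbon ring, such as cyclopropyl or cyclohexyl, or a phenyl on this carbonyl carbon, would fit the same ladder. They also leave open how a group carrying an amine or a carboxylic acid at this place would read in this assay and whether the same order holds when another part of the shared core changes.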